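Acetylating a ring hydroxy group in a cytotoxic lactone series

A few compounds are considered here, and "the series" means these few. Any claim that something is new, unique, unknown or untested is made for them only; others in the source may bear on it.

Compound 1, `C=C1[C@@H](C/C=C2/C(=O)OC[C@H]2OC(C)=O)[C@]2(C)CC[C@@H](OC(C)=O)[C@@](C)(CO[Si](C)(C)C(C)(C)C)[C@H]2C[C@@H]1O`, was tested in a functional assay on A549 cells (Homo sapiens) for cytotoxicity, read by sulforhodamine B assay (a lower number here means a stronger inhibitor, a higher number a weaker inhibitor), and gave 6850 nM. Of the two values recorded so far, this is the higher number, but the nearest neighbour, compound 2 with the structure `C=C1[C@@H](OC(C)=O)C[C@@H]2[C@](C)(CO[Si](C)(C)C(C)(C)C)[C@H](OC(C)=O)CC[C@@]2(C)[C@@H]1C[C@@H](Nc1ccc(C(=O)O)cc1)C1=CCOC1=O`, gives 4210 nM, a reading within the usual scatter of compound 1, so the two are best regarded as indistinguishable on these data.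

Compound 3, `C=C1[C@@H](OC(C)=O)C[C@@H]2[C@](C)(CO[Si](C)(C)C(C)(C)C)[C@H](OC(C)=O)CC[C@@]2(C)[C@@H]1C/C=C1/C(=O)OC[C@H]1OC(C)=O`, has not yet been measured. It differs from compound 1 in one place: acetyl in place of hydrogen on an oxygen on a saturated carbon. Going by the values given here, no pair of measured compounds differing in a single place is available to calibrate such a change, so the only guidance is the narrow spread of the two existing values.

For compound 3 the expected step of a 1.2-fold lower number from compound 1 to compound 3 (0.10 log units; within the scatter) is small and in no clear direction, most likely inside the scatter. Compound 3 is therefore estimated at 5500 nM, with a plausible range from 2200 nM to 14000 nM.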

Compound 3, half-maximal inhibitory concentration: 4640 nM
The estimate for compound 3 lay 1.2-fold (0.07 log units) above the measured number; the range from low to high includes it.
By their numbers in this assay, from the lowest: compounds 2, 3 and 1 (each within the scatter of the next).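

Replacing hydrogen with acetyl on this oxygen on a saturated carbon gives a 1.5-fold lower number from compound 1 to compound 3 (0.17 log units; within the scatter) in this assay. Going by these compounds alone, this is the first pair that differs in one place, so the effect of this change can now be read directly rather than inferred from the spread of unrelated values. On this evidence, the free hydroxy is not required at this position for the cytotoxicity seen here, since hydroxy and acetoxy cannot be told apart, and no measurement at hand offers an explanation.

From the compounds shown here alone, what a methoxy group, a longer ester such as butyryloxy, or an amine would do at this position remains open. A single pair also cannot show whether the same swap would behave alike in other compounds of the series.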